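The source may report more compounds than this note shows. Statements on the series, on what has been measured and on what is new or still open speak of the compounds shown alone.

Working notes on the series. Three compounds have numbers in a functional assay, with a stated time of 20 min; on this read-out lower numbers stand for stronger inhibition and higher numbers for weaker inhibition. Compound 1 `CSc1nc(-c2cccs2)c(C#N)c(=O)n1C` gives 71 ug/mL; compound 2 `CCOC(=O)c1cnn(-c2nc(-c3ccc(Cl)cc3)c(C#N)c(=O)n2C)c1N` gives 64 ug/mL; compound 3 `Cn1c(NN)nc(-c2ccc(Cl)cc2)c(C#N)c1=O` gives 44 ug/mL. Compound 2 stands second highest of the three numbers: nearest is compound 1, within the scatter, and furthest is compound 3, also within the scatter. For the measured compounds named here, no pair of measured compounds differs in a single place, so no step size is established from measurement.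

Compound 4 `CCOC(=O)c1cnn(-c2nc(-c3cccs3)c(C#N)c(=O)n2C)c1N` differs from compound 2 as follows: thiophen-2-yl in place of 4-chlorophenyl on an aromatic carbon. Compound 1, whose core already carries thiophen-2-yl, sits within the scatter of compound 2, so the step of a 1.1-fold higher number from compound 2 to compound 4 (0.03 log units; within the scatter) is expected to stay within the scatter, without a clear direction. For compound 4 the estimate in this assay is 68 ug/mL, with a range of 35 ug/mL to 135 ug/mL.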

Compound 4, half-maximal inhibitory concentration: 79 ug/mL
Beside the measured number, compound 4's estimate is 1.2-fold (0.07 log units) below it, within the range that was stated.
By their numbers in this assay, from the lowest: compounds 3, 2, 1 and 4 (each within the scatter of the next).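

In this assay, for the compounds shown here, thiophen-2-yl in place of 4-chlorophenyl gives a 1.2-fold higher number from compound 2 to compound 4 (0.09 log units; within the scatter) as the first reading of a single change. At this aromatic carbon, ortho to a cyano group, the two aromatic rings are therefore not told apart on this read-out. No measurement at hand bears on why they read alike.

As far as these compounds go, whether this position stays as flat with an amine, a carboxylic acid or a longer chain remains open. Also open, from the compounds shown here alone, is whether the same exchange reads alike with another group on the shared core.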